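Pyrimidinyl thiourea series: methoxy to methyl step

The source may hold more compounds than are shown below. What is called first, only, known or untested is meant among the compounds shown, and "the series" means these compounds.

Compound 1 `COc1cc(Cl)nc(NC(=S)NC(=O)c2c(-c3ccc(Cl)cc3Cl)noc2C)n1` gives 14.6% in a functional assay on the whole organism for inhibition, with Digitaria ciliaris as the target, with a stated time of 72 h, tested at 10 mg/L; on this read-out lower numbers stand for less inhibition of growth and higher numbers for more inhibition of growth at the one concentration tested. Compound 2 `Cc1cc(Cl)nc(NC(=S)NC(=O)c2c(-c3ccc(Cl)cc3Cl)noc2C)n1` gives 10.2% in this assay; its difference from compound 1 is methyl in place of methoxy on an aromatic carbon, and a number 4.4 percentage points lower from compound 1 to compound 2 (within the scatter). Compound 3 `COc1cc(OC)nc(NC(=S)NC(=O)c2c(-c3ccc(Cl)cc3Cl)noc2C)n1` differs from compound 1 by methoxy in place of chloro on an aromatic carbon. In this assay compound 3 gives 32%, with a number 17.4 percentage points higher from compound 1 to compound 3 (beyond the scatter) and a number 21.8 percentage points higher from compound 2 to compound 3 (beyond the scatter). Compound 4 `COc1cc(C)nc(NC(=S)NC(=O)c2c(-c3ccc(Cl)cc3Cl)noc2C)n1` is not yet measured; its difference from compound 3 is methyl in place of methoxy on an aromatic carbon. This is the same kind of change as that from compound 1 to compound 2, but the surroundings differ: there the carbon was meta to a chloro group (1 heavy atom), here it is meta to a methoxy group (2 heavy atoms). For compound 4 the expected step is a number 4 percentage points lower from compound 3 to compound 4 (within the scatter), resting on compound 1 and compound 2, where a number 4.4 percentage points lower from compound 1 to compound 2 (within the scatter). Compound 4 is therefore estimated at 28% in this assay, between 15% and 42%.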

Compound 4, percent growth inhibition at one concentration: 30.2%
Beside the measured number, compound 4's estimate is 2.2 percentage points below it; the measured number falls inside the stated range.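

In this assay, methyl in place of methoxy again gives no step beyond the scatter on a second core, with a number 1.8 percentage points lower from compound 3 to compound 4 (within the scatter): the same change on two cores in this assay, a number 4.4 percentage points lower (within the scatter) from compound 1 to compound 2 and a number 1.8 percentage points lower (within the scatter) from compound 3 to compound 4, 2.6 percentage points apart, within the scatter of two such steps. Methoxy in place of chloro also carries across the two cores, with a number 20 percentage points higher from compound 2 to compound 4 (beyond the scatter): the same change on two cores in this assay, a number 17.4 percentage points higher (beyond the scatter) from compound 1 to compound 3 and a number 20 percentage points higher (beyond the scatter) from compound 2 to compound 4, 2.6 percentage points apart, within the scatter of two such steps. Methyl in place of chloro, with a number 15.6 percentage points higher from compound 1 to compound 4 (beyond the scatter), has no counterpart on a second core, and agreement across these four compounds at a single concentration does not establish a rule for the wider series.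

The compounds shown carry only methoxy, methyl and chloro at the changing places. As far as these compounds go, how an amine or a longer chain would behave there remains open.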